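Allyl to Benzyl: From Compound 1 to Compound 3

The source may hold more compounds than are shown below. What is called first, only, known or untested is meant among the compounds shown, and "the series" means these compounds.

Compound 1 `C=CCONC(=O)Cn1cc(C(=O)NCC(=O)N[C@@H](CC(C)C)C(=O)O)c2ccccc21` was tested in a functional assay on MRC5 cells (Homo sapiens) for inhibition, read by microscopy and resazurin assay, with a stated time of 72 h; a higher number here means a weaker inhibitor, a lower number a stronger inhibitor. In this assay compound 1 gives only a limit, > 128000 nM. Its relative compound 2 `C=CCONC(=O)Cn1cc(C(=O)N[C@@H](C)C(=O)N[C@@H](CC(C)C)C(=O)O)c2ccccc21` carries methyl in place of hydrogen on a saturated chain carbon bound to an amide-type nitrogen and a carbonyl carbon. In this assay compound 2 also gives only a limit, > 128000 nM. The step that the two limits leave unreadable from compound 1 to compound 2 therefore cannot be sized, as the limit of > 128000 nM in this assay, at which 2 of the 2 values shown sit, shows. Compound 3 `CC(C)C[C@H](NC(=O)CNC(=O)c1cn(CC(=O)NOCc2ccccc2)c2ccccc12)C(=O)O` differs from compound 1 by phenyl in place of vinyl on a saturated chain carbon bound to an oxygen on an unsaturated carbon. Going by the values given here, no measured step bears on that change, so no direction beyond the scatter can be claimed, and a limit remains likely. Compound 3 is expected to give about 150000 nM, between 60000 nM and 400000 nM. This corresponds to an expected step that the limit leaves unreadable from compound 1 to compound 3.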

Compound 3, half-maximal inhibitory concentration: > 128000 nM
Compound 3: a limit, no number; the forecaster's own chance of this, stated with the estimate: 80%; the middle value lies beyond the limit too.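

Going by these compounds alone, no step from compound 1 to compound 3 can be read, because both compounds give only a limit: the limit of > 128000 nM in this assay, at which 3 of the 3 values shown sit. Going by these compounds, whether swapping allyl for benzyl changes inhibition in this assay at all stays open.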